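The source may report more compounds than this note shows. Statements on the series, on what has been measured and on what is new or still open speak of the compounds shown alone.

Of the compounds shown here, three have so far been tested in a functional assay on HCT-116 cells (Homo sapiens) for positive allosteric modulation, read by MTT assay, with stated times of 24 h and 48 h, tested at 2.5 uM; on this read-out higher numbers stand for more inhibition of growth at the one concentration tested and lower numbers for less inhibition of growth. Compound 1 `CS(=O)(=O)c1ccc(-c2cnc3[nH]cc(-c4nnc(-c5ccccc5)o4)c(=O)c3c2)cc1` gives 27.2%, compound 2 `CS(=O)(=O)c1ccc(-c2cnc3[nH]cc(-c4nnc(-c5cccnc5)o4)c(=O)c3c2)cc1` gives 28.6%, and compound 3 `O=c1c(-c2nnc(-c3ccc(Cl)cc3)o2)c[nH]c2ncc(-c3cccnc3)cc12` gives 20.1%. From compound 2 to compound 1 the change is phenyl in place of pyridin-3-yl on an aromatic carbon, and it made a step of a number 1.4 percentage points lower from compound 2 to compound 1 (within the scatter). The difference between the core of compound 2 and that of compound 3 is not broken down here. Compound 4 `O=c1c(-c2nnc(-c3ccc(Cl)cc3)o2)c[nH]c2ncc(-c3ccccc3)cc12` has not yet been measured; it differs from compound 3 by phenyl in place of pyridin-3-yl on an aromatic carbon. This is the same kind of change as before, but here the place is on a six-membered aromatic ring with 1 nitrogen, part of a fused or bridged system of two rings, rather than on a five-membered aromatic ring with 2 nitrogen and 1 oxygen. Because the earlier step was a number 1.4 percentage points lower from compound 2 to compound 1 (within the scatter), an equally small step is expected here, a number 1.1 percentage points lower from compound 3 to compound 4 (within the scatter). Compound 4 is therefore estimated at 19%, with a likely range from 9% to 30%.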

Compound 4, percent growth inhibition at one concentration: 29.8%
Compound 4: the middle estimate sits 10.8 percentage points below what was measured, within the range that was stated.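

In this assay, putting phenyl in place of pyridin-3-yl on the ring carbon gave a number 9.7 percentage points higher from compound 3 to compound 4 (within the scatter). Set beside the earlier case, the two steps do not differ beyond what repeated measurement would give: the same change on two cores in this assay, a number 1.4 percentage points lower (within the scatter) from compound 2 to compound 1 and a number 9.7 percentage points higher (within the scatter) from compound 3 to compound 4, 11.1 percentage points apart, within the scatter of two such steps. This gives no sign that the change behaves differently on the two cores, but it does not show that the two steps are the same or that the change has any real effect on either core.

The compounds shown leave open whether a different group at this aromatic carbon, such as an amine or a carboxylic acid, would give a step beyond the scatter. They also leave open how the same change would behave on a further core.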